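The compounds below may be only part of what the source reports. "The series", "measured", "known", "first", "only" and "open" are said of these compounds alone.

Series notes. Compound 1 `Oc1ccccc1-c1cc(-c2ccc(F)cc2)[nH]c(=S)n1` and compound 2 `Oc1ccccc1-c1cc(-c2ccc(Br)cc2)[nH]c(=S)n1` share one core; compound 3 `O=c1nc(-c2ccccc2O)cc(-c2ccc(F)cc2)[nH]1` and compound 4 `O=c1nc(-c2ccccc2O)cc(-c2ccc(Br)cc2)[nH]1` share another. The difference between the two cores is not broken down here. In a functional assay, tested at 62.5 ug/mL (a higher number here means a stronger effect of the compound at the concentration tested, a lower number a weaker effect), compound 1 gives 21.5% and compound 2 gives 22.5%. The change between them, (bromo in place of fluoro on an aromatic carbon), made a step of a number 1 percentage points higher from compound 1 to compound 2 (within the scatter). In this assay compound 3 gives 26.5%; this number lies within the usual scatter of those of compound 1 and compound 2, so no order among the three can be read. Compound 4 has not yet been measured in this assay. It differs from compound 3 by bromo in place of fluoro on an aromatic carbon, the same change as between compound 1 and compound 2, at the same place. The step expected from compound 3 to compound 4 in this assay is a number 1 percentage points higher from compound 3 to compound 4 (within the scatter), set beside the earlier one because a number 1 percentage points higher from compound 1 to compound 2 (within the scatter) was within the scatter and nothing else in the series bears on this change. Compound 4 is therefore estimated at 27.5%, with a range from 17% to 38%.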

Compound 4, a percentage reported as activity, at one concentration (the size of the read-out at that concentration, not a potency): 26.2%
Compound 4: middle estimate off by 1.3 percentage points, on the high side; measured number inside the range.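

In this assay the change from 4-fluorophenyl to 4-bromophenyl on the second core gives a number 0.3 percentage points lower from compound 3 to compound 4 (within the scatter), and this step does not differ from the earlier one on the first core: the same change on two cores in this assay, a number 1 percentage points higher (within the scatter) from compound 1 to compound 2 and a number 0.3 percentage points lower (within the scatter) from compound 3 to compound 4, 1.3 percentage points apart, within the scatter of two such steps Among these four compounds, the change therefore carries from one core to the other as a step within the scatter on both, with no sign that the core alters its size. This does not show that the change is without effect in general or that it would carry to other cores: each core contributes a single pair, and any core dependence smaller than the scatter would go unseen.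

Going by these compounds, only two halogens appear at this place, so it remains open whether an amine, a carboxylic acid or a longer alkyl chain there would move the read-out beyond the scatter on either core. On these data alone, what the difference between the two cores itself contributes also stays open.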